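The compounds below may be only part of what the source reports. "The series", "measured", "known", "first", "only" and "open" are said of these compounds alone.

Measured compounds:
Compound 1 `O=C(Nc1cccc(-n2cc(-c3ccncc3)c(-c3ccc(Cl)c(O)c3)n2)c1)Nc1cccc(C(F)(F)F)c1`, in a functional assay on DU-145 cells (Homo sapiens) for inhibition, read by sulforhodamine B assay, with a stated time of 48 h (a lower number here means that less compound is tolerated, a higher number that more compound is tolerated), compound 1 gives > 32500 nM, which is a limit of the assay.
Compound 2 `COc1cc(-c2nn(-c3cccc(NC(=O)c4cccc(C(F)(F)F)c4)c3)cc2-c2ccncc2)ccc1Cl`, in this assay compound 2 gives > 50000 nM, which is a limit of the assay.

Both measured compounds sit at limits rather than at numbers (the limit of > 32500 nM in this assay, at which 1 of the 2 values shown sits; (the limit of > 50000 nM in this assay, at which 1 of the 2 values shown sits)). Going by the values given here, compound 2 therefore stands only as a limit in this assay, and the other value shown is a limit as well, so no step between measured compounds can be read and no direction of change is visible.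

Compound 3 `COc1cc(-c2nn(-c3cccc(NC(=O)Nc4cccc(C(F)(F)F)c4)c3)cc2-c2ccncc2)ccc1Cl` has not yet been measured in this assay. It differs from compound 2 by (3-(trifluoromethyl)phenyl)amino in place of 3-(trifluoromethyl)phenyl on a carbonyl carbon. Compound 1 already carries this same kind of carbonyl carbon flanked by two amide-type nitrogens, and compound 1 gives only a limit, > 32500 nM. Since neither measured compound shows a number, no step beyond the scatter is expected from compound 2 to compound 3, estimated as a number no higher from compound 2 to compound 3 (the limit leaves the size open). Compound 3 is expected to come out near 50000 nM, within a range from 20000 nM to 100000 nM, most likely again reported as a limit.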

Compound 3, concentration lethal to 50% of the cells: > 50000 nM
Compound 3 was reported as a limit; the forecaster's own chance of this, stated with the estimate: 80%; the middle value sits exactly at the limit.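

In this assay compound 3 gives > 50000 nM, which is a limit of the assay. Going by these compounds alone, compound 1 and compound 2 also stand only as limits, so no step from either of them to compound 3 can be read. The compounds shown leave open whether putting (3-(trifluoromethyl)phenyl)amino in place of 3-(trifluoromethyl)phenyl, or methyl in place of hydrogen on the oxygen, changes the result at all.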